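Brominated furanone series: hydroxy removal on the butyl chain

The source may report more compounds than this note shows. Statements on the series, on what has been measured and on what is new or still open speak of the compounds shown alone.

Measured compounds in a functional assay on P388 cells (Mus musculus) for cytotoxicity; on this read-out higher numbers stand for an effect only at larger amounts of compound and lower numbers for an effect already at smaller amounts:
compound 1, `CCC[C@@H](OC(C)=O)C1=C(Br)C(=C(Br)Br)OC1=O`: "not determined" (no result reported)
compound 2, `CCC[C@@H](O)C1=C(Br)C(=C(Br)Br)OC1=O`: "not determined" (no result reported)
compound 3, `CCCCC1=C(Br)/C(=C/Br)OC1=O`: > 5 ug/mL, a limit of the assay

Among the compounds with values here, compound 2 stands without a number in this assay; its entry is blank, as is that of compound 1, and the only other value shown for the series is a limit. Compound 3 gives > 5 ug/mL in this assay, which is a limit and not a measured number; this is the limit of > 5 ug/mL in this assay, at which 1 of the 3 values shown sits.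

Compound 4, `CCCCC1=C(Br)C(=C(Br)Br)OC1=O`, differs from compound 2 by hydrogen in place of hydroxy on a saturated chain carbon bound to a double-bonded ring carbon and a saturated chain carbon. Within the data shown here, no step between measured compounds is available, and compound 2 carries no number, so no size or direction of the step in this assay can be drawn from compound 2; nothing beyond the usual scatter is assumed.

Compound 4 is expected to give 8 ug/mL in this assay, with an estimated range from 3 ug/mL to 30 ug/mL. This expectation rests on compound 3 and its limit of > 5 ug/mL, the closest measured structure.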

Compound 4, concentration for half-maximal effect: > 5 ug/mL
Compound 4 was reported as a limit; the forecaster's own chance of this, stated with the estimate: 60%; the middle value lies beyond the limit too.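

In this assay compound 4 gives > 5 ug/mL, a limit and not a number. Compound 2 carries no number there, so no step can be read between compound 2 and compound 4. The compounds shown leave open what the change from 1-hydroxybutyl to butyl does in this assay.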